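Compound 3 to compound 4: a pyridine isomer swap

The compounds below may be only part of what the source reports. "The series", "measured", "known", "first", "only" and "open" are said of these compounds alone.

Measured so far in a functional assay on MCF7 cells (Homo sapiens) for inhibition, read by CCK-8 assay, with a stated time of 4 days; a higher number here means a weaker inhibitor, a lower number a stronger inhibitor
compound 1 `COc1cc(C(=O)O)ccc1NC(=O)[C@@H]1N[C@@H](CC(C)(C)C)[C@](CNCc2ccc(O)cc2)(c2ccc(Cl)cc2F)[C@H]1c1cccc(Cl)c1F` gives 830 nM
compound 2 `COc1cc(C(=O)O)ccc1NC(=O)[C@@H]1N[C@@H](CC(C)(C)C)[C@](C)(c2ccc(Cl)cc2F)[C@H]1c1cccc(Cl)c1F` gives 1870 nM
compound 3 `COc1cc(C(=O)O)ccc1NC(=O)[C@@H]1N[C@@H](CC(C)(C)C)[C@](CNCc2ccccn2)(c2ccc(Cl)cc2F)[C@H]1c1cccc(Cl)c1F` gives 720 nM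

Compound 3 gives 720 nM and shares the low end of the range with compound 1, the two lying within the scatter of each other. The clear gap in the series is a 2.6-fold lower number from compound 2 to compound 3 (0.41 log units; beyond the scatter), a modest step.

Compound 4 `COc1cc(C(=O)O)ccc1NC(=O)[C@@H]1N[C@@H](CC(C)(C)C)[C@](CNCc2cccnc2)(c2ccc(Cl)cc2F)[C@H]1c1cccc(Cl)c1F` carries one change from compound 3: pyridin-3-yl in place of pyridin-2-yl on a saturated chain carbon bound to an amine nitrogen. This places pyridin-3-yl in place of pyridin-2-yl on a saturated chain carbon bound to an amine nitrogen.

The closest measured precedent is the exchange at that same place, which gave a 1.2-fold lower number from compound 1 to compound 3 (0.06 log units; within the scatter). The two steps that add or remove the whole amino substituent, a 2.3-fold higher number from compound 1 to compound 2 (0.35 log units; beyond the scatter) and a 2.6-fold lower number from compound 2 to compound 3 (0.41 log units; beyond the scatter), are modest, and the change in compound 4 removes no such substituent. Within the data shown here, no pair of pyridine isomers has been measured yet, so this rests on one exchange only.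

In this assay the expected result is no shift beyond the scatter, with an estimated 1.0-fold higher number from compound 3 to compound 4 (0.02 log units; within the scatter). The value expected for compound 4 is 750 nM, within an estimated range of 400 nM to 1350 nM.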

Compound 4, half-maximal inhibitory concentration: 1140 nM
Beside the measured number, compound 4's estimate is 1.5-fold (0.18 log units) below it; low and high end bracket the measured number.
By their numbers in this assay, from the lowest: compounds 3, 1, 4 and 2 (each within the scatter of the next, the first and the last beyond it).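

In this assay the exchange of pyridin-2-yl for pyridin-3-yl on a saturated chain carbon bound to an amine nitrogen gives a 1.6-fold higher number from compound 3 to compound 4 (0.20 log units; within the scatter) and the exchange of 4-hydroxyphenyl for pyridin-3-yl gives a 1.4-fold higher number from compound 1 to compound 4 (0.14 log units; within the scatter) so neither exchange separates the compounds at this place. The new point concerns the whole substituent: adding ((pyridin-3-yl)methyl)amino in place of hydrogen gives a 1.6-fold lower number from compound 2 to compound 4 (0.21 log units; within the scatter) whereas the (4-hydroxybenzyl)amino and ((pyridin-2-yl)methyl)amino versions of that step were printed as beyond the scatter, so the modest separation from compound 2 does not hold for all three amino substituents. No data at hand bear on why the pyridin-3-yl compound falls within the scatter of compound 2.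

Still open, on these data alone, is whether pyridin-4-yl or unsubstituted phenyl on the same chain carbon would stay within the scatter of these aryl groups. Also open, as far as these compounds go, is what a longer chain between the amine nitrogen and the ring, or a tertiary amine at that nitrogen, would do in this assay on the same core.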